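From Methoxy to 4-Fluorophenoxy in a Thiourea Series

The source may hold more compounds than are shown below. What is called first, only, known or untested is meant among the compounds shown, and "the series" means these compounds.

Compound 1 `COc1ccnc(N2CCC(NC(=S)Nc3cccnc3)CC2)c1` was tested in an assay on membranes from brain for binding affinity to Lysophosphatidylserine lipase ABHD12 (Mus musculus), read by fluorescence, with a stated time of 20 min; on this read-out lower numbers stand for stronger inhibition and higher numbers for weaker inhibition. In this assay compound 1 gives > 5000 nM, which is a limit of the assay rather than a number. Compound 2 `FC(F)(F)c1cccnc1N1CCC(NC(=S)Nc2cccnc2)CC1` also gives > 5000 nM in this assay, again a limit. Compound 3 `FC(F)(F)Oc1ccccc1Oc1ccnc(N2CCC(NC(=S)Nc3cccnc3)CC2)c1Cl` gives 96 nM in this assay. Compound 1 therefore stands at the limit of > 5000 nM in this assay, at which 2 of the 3 values shown sit. Compound 4 `Fc1ccc(Oc2ccnc(N3CCC(NC(=S)Nc4cccnc4)CC3)c2)cc1` differs from compound 1 by 4-fluorophenyl in place of methyl on an oxygen on an aromatic ring. For the measured compounds named here, no measured step of this kind exists among the three compounds. The expected step is an at least 8.3-fold lower number from compound 1 to compound 4 (0.92 log units; beyond the scatter), toward stronger inhibition, since compound 3 reaches 96 nM in this assay. Compound 4 is expected to give about 600 nM in this assay, within a range from 150 nM to 3000 nM.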

Compound 4, half-maximal inhibitory concentration: 1400 nM
Compound 4: the middle estimate sits 2.3-fold (0.37 log units) below what was measured; low and high end bracket the measured number.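

In this assay, for the compounds shown here, the change to 4-fluorophenyl in place of methyl on an oxygen on an aromatic ring gives an at least 3.5-fold lower number from compound 1 to compound 4 (0.55 log units; beyond the scatter) and thus the first measured change at this place. Compound 4 gives a number on the shared core, whereas the methoxy group of compound 1 gives only a limit. The size of the step is therefore a bound and not an exact figure: the limit of > 5000 nM in this assay, at which 2 of the 4 values shown sit.

Whether the fluorine contributes remains open, since an unsubstituted phenoxy group is not among the compounds shown. From the compounds shown here alone, whether a benzyloxy group or an amine at this place would do as well also remains open.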